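This account rests on a few compounds, and the source may have more. Where it says the series, first, only, none or still open, it means among the compounds named here.

In an assay on HEK293 cells for inhibition of N-acylethanolamine-hydrolyzing acid amidase (Rattus norvegicus), read by LC-MS, with a stated time of 30 min (a lower number here means a stronger inhibitor, a higher number a weaker inhibitor), compound 1 `CSc1cccc(CCCCCC(=O)N2CCOC2=O)c1` gives 12800 nM and compound 2 `O=C(CCCCCc1cccc(O)c1)N1CCOC1=O` gives 8640 nM. Compound 3 `O=C(CCCCCc1cccc(CO)c1)N1CCOC1=O` reaches only > 20000 nM, which is a limit of the assay and not a number. Compound 3 thus stands at the limit of > 20000 nM in this assay, at which 1 of the 3 values shown sits. Going from hydroxy to hydroxymethyl gave an at least 2.3-fold higher number from compound 2 to compound 3 (0.36 log units; beyond the scatter), while going from methylsulfanyl to hydroxymethyl gave an at least 1.5-fold higher number from compound 1 to compound 3 (0.19 log units; that floor lies within the scatter). Compound 4 `O=C(O)c1cccc(CCCCCC(=O)N2CCOC2=O)c1` differs from compound 3 by carboxy in place of hydroxymethyl on an aromatic carbon. Within the data shown here, no measured step introduces a carboxy group, so the measured steps show only that the hydroxymethyl group in compound 3 weakened inhibition relative to compound 2. Compound 4 is therefore expected to stay near that limit, with a step that the limit leaves unreadable from compound 3 to compound 4 as the expected step. The estimate for compound 4 in this assay is 25000 nM, between 10000 nM and 60000 nM.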

Compound 4, half-maximal inhibitory concentration: > 20000 nM
Compound 4 gave a limit, no number (the forecaster's own chance of this, stated with the estimate: 65%); the middle value is on the limit's open side.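

In this assay, compound 4 also ends at a limit and not a number, so a second group at this place leaves inhibition out of reach of the assay: the limit of > 20000 nM in this assay, at which 2 of the 4 values shown sit. Carboxy in place of hydroxy gave an at least 2.3-fold higher number from compound 2 to compound 4 (0.36 log units; beyond the scatter), so this change does weaken inhibition. Carboxy in place of methylsulfanyl gave an at least 1.5-fold higher number from compound 1 to compound 4 (0.19 log units; that floor lies within the scatter), which alone shows no clear loss.

The step between the two limits cannot be read, so carboxy and hydroxymethyl cannot be ranked. From the compounds shown here alone, whether an amine or a methoxy group at this place would give a measurable number stays open.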